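Replacing 3-acetamidophenyl with 2-chlorophenyl

The compounds below may be only part of what the source reports. "The series", "measured", "known", "first", "only" and "open" are said of these compounds alone.

Values measured in a functional assay on HL-60 cells (Homo sapiens) for inhibition, read by MTT assay, with a stated time of 72 h; on this read-out lower numbers stand for stronger inhibition and higher numbers for weaker inhibition
- compound 1 `Cc1nc(-c2ccc(F)cc2)c(C(=O)N2CCN(c3cccc(Cl)c3)CC2)o1` gives 40.1 nM
- compound 2 `Cc1nc(-c2cccc(F)c2)c(C(=O)N2CCN(c3cccc(Cl)c3)CC2)o1` gives 33.7 nM
- compound 3 `CC(=O)Nc1cccc(-c2nc(C)oc2C(=O)N2CCN(c3cccc(Cl)c3)CC2)c1` gives 208 nM

Compound 3 stands highest of the three, with a 5.2-fold higher number from compound 1 to compound 3 (0.71 log units; beyond the scatter) and with a 6.2-fold higher number from compound 2 to compound 3 (0.79 log units; beyond the scatter) as well. Compound 4 `Cc1nc(-c2ccccc2Cl)c(C(=O)N2CCN(c3cccc(Cl)c3)CC2)o1` carries 2-chlorophenyl in place of 3-acetamidophenyl on an aromatic carbon. For the measured compounds named here, three measured steps bear on this change. The two just given, both modest, separate compound 3 from the fluorophenyl compounds. The third, a 1.2-fold lower number from compound 1 to compound 2 (0.08 log units; within the scatter), shows no separation between those two compounds. Going by the values given here, no measured compound carries a 2-chlorophenyl group, so the comparison with the fluorophenyl compounds is only an approximate guide. Compound 4 is nevertheless expected to lie closer to compound 1 (40.1 nM) than to compound 3 (208 nM). A modest move to a lower number is therefore expected in this assay, estimated as a 3.5-fold lower number from compound 3 to compound 4 (0.54 log units; beyond the scatter) overall. Compound 4 is estimated at 60 nM with an expected range from 20 nM to 180 nM in this read-out.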

Compound 4, half-maximal inhibitory concentration: 132 nM
For compound 4 the middle estimate is 2.2-fold (0.34 log units) below the measured one; low and high end bracket the measured number.
By their numbers in this assay, from the lowest: compounds 2 and 1 (each within the scatter of the next); then compounds 4 and 3 (each within the scatter of the next).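

In this assay the 2-chlorophenyl group of compound 4 does not separate from the 3-acetamidophenyl group of compound 3 (a 1.6-fold lower number from compound 3 to compound 4 (0.20 log units; within the scatter)), so at this position the hydrogen-bond donor and acceptor of 3-acetamidophenyl can leave without a step beyond the scatter. The gap from the fluorophenyl compounds, until now seen only for compound 3, also appears with this smaller group that has no donor or acceptor (a 3.9-fold higher number from compound 2 to compound 4 (0.59 log units; beyond the scatter); a 3.3-fold higher number from compound 1 to compound 4 (0.52 log units; beyond the scatter)). Nothing available explains these steps.

The compounds shown do not tell the effect of chlorine from that of its place on the phenyl ring, which 2-fluorophenyl or 3-chlorophenyl would help to separate. Also open, from the compounds shown here alone, is how an unsubstituted phenyl, or a phenyl carrying an amine or a carboxylic acid, would stand at this position.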